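The source may hold more compounds than are shown below. What is called first, only, known or untested is meant among the compounds shown, and "the series" means these compounds.

Measured compounds:
- compound 1 `O=C(O)c1ccccc1-c1ccc(CCc2ncc(CCC3CCCCC3)[nH]2)cc1` gives 33 nM in an in vitro functional assay on cells for agonist activity at Bombesin receptor subtype-3 (Mus musculus), read by luminescence and calcium flux; on this read-out higher numbers stand for an effect only at larger amounts of compound and lower numbers for an effect already at smaller amounts
- compound 2 `CC(C)(C)CCc1cnc(CCc2ccc(-c3ccccc3C(=O)O)cc2)[nH]1` gives 6.2 nM in this assay

Compound 1 stands highest of the two numbers in this assay; its nearest neighbour is compound 2, reached by a 5.3-fold lower number from compound 1 to compound 2 (0.73 log units; beyond the scatter), a change of tert-butyl in place of cyclohexyl on a saturated chain carbon, two bonds along the chain from an aromatic carbon. Compound 3 `N#Cc1ccc(Cc2cnc(CCc3ccc(-c4ccccc4C(=O)O)cc3)[nH]2)cc1` is not yet measured. It differs from compound 1 by 4-cyanophenyl in place of cyclohexylmethyl on a saturated chain carbon bound to an aromatic carbon. Among the measured compounds shown here, no measured step covers this exchange; the one step known, from compound 1 to compound 2, touches the same chain region and shows that a change there can move the number beyond the scatter, but the groups involved differ from those in compound 3. The expected step for compound 3 is therefore uncertain and a 1.2-fold higher number from compound 1 to compound 3 (0.08 log units; within the scatter) is put near no change, with a wide range. Compound 3 is estimated at 40 nM, between 8 nM and 200 nM.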

Compound 3, half-maximal effective concentration: 723 nM
Beside the measured number, compound 3's estimate is 18-fold (1.26 log units) below it, outside the stated range (above it).
By their numbers in this assay, from the lowest: compound 2; then compound 1; then compound 3.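

In this assay, the position on a saturated chain carbon bound to an aromatic carbon proves much less tolerant than the earlier exchange of saturated groups suggested: 4-cyanophenyl in place of cyclohexylmethyl brings a 22-fold higher number from compound 1 to compound 3 (1.34 log units; beyond the scatter) and 4-cyanophenyl in place of neopentyl brings a 120-fold higher number from compound 2 to compound 3 (2.07 log units; beyond the scatter) in this comparison. Among the compounds shown here, both steps are larger than a 5.3-fold lower number from compound 1 to compound 2 (0.73 log units; beyond the scatter) among the saturated groups, so the aromatic nitrile-bearing group is the first replacement here to cost this much. Nothing shown here accounts for the rise.

The exchange, read one bond further out as 2-cyclohexylethyl to 4-cyanobenzyl, changes the ring, the nitrile and the link at once, so the compounds shown cannot say which of these carries the step. A plain benzyl group, a 2-phenylethyl group or a 4-cyanophenyl group on a longer chain would separate these three changes.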